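Swapping dimethylamino for chloro on the lactam ring

The source may report more compounds than this note shows. Statements on the series, on what has been measured and on what is new or still open speak of the compounds shown alone.

Compound 3 `COc1cccc(OC)c1[C@@H]1C[C@@H](N(C)C)C(=O)N1Cc1ccc(OC(F)(F)F)cc1` gives 3620 nM in a functional assay on CHO cells for antagonist activity at Orexin/Hypocretin receptor type 1 (Homo sapiens), read by FLIPR and calcium flux (a higher number here means a weaker inhibitor, a lower number a stronger inhibitor), the highest number among the three measured compounds. Its nearest neighbour is compound 1 `CN[C@@H]1C[C@@H](c2c(OC)cccc2OC)N(Cc2ccc(OC(F)(F)F)cc2)C1=O`, which in this assay gives 2400 nM; the step of a 1.5-fold higher number from compound 1 to compound 3 (0.18 log units; within the scatter) stays within the scatter. Furthest away is compound 2 `COc1cccc(OC)c1[C@@H]1C[C@H](Cl)C(=O)N1Cc1ccc(OC(F)(F)F)cc1`, which in this assay gives 65 nM.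

Compound 4 `COc1cccc(OC)c1[C@@H]1C[C@@H](Cl)C(=O)N1Cc1ccc(OC(F)(F)F)cc1` differs from compound 3 by chloro in place of dimethylamino on a saturated ring carbon. Among the measured compounds shown here, the only measured step, from compound 1 to compound 3, concerns a methyl on an amine nitrogen and is a different change, so it offers little guidance. Compound 2 also carries a chloro group and shows a far lower number than compound 3, though it is not identical to compound 4 in all respects, so its value is a pointer rather than a measured step.

On this basis compound 4 is expected to show a markedly lower number than compound 3, a step of about a 24-fold lower number from compound 3 to compound 4 (1.38 log units; beyond the scatter), with the estimate for compound 4 placed at 150 nM and a range from 30 nM to 800 nM.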

Compound 4, half-maximal inhibitory concentration: 177 nM
Compound 4: middle estimate off by 1.2-fold (0.07 log units), on the low side; low and high end bracket the measured number.
By their numbers in this assay, from the lowest: compound 2; then compound 4; then compounds 1 and 3 (each within the scatter of the next).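

In this assay, the large gain at this saturated ring carbon comes with chloro replacing either amine: the step is a 20-fold lower number from compound 3 to compound 4 (1.31 log units; beyond the scatter) for dimethylamino and a 14-fold lower number from compound 1 to compound 4 (1.13 log units; beyond the scatter) for methylamino, whereas the methyl on the amine nitrogen had made no change beyond the scatter. Configuration at this carbon counts as well, though by less, with the chloro compound drawn S giving the lower number. The step of a 2.7-fold higher number from compound 2 to compound 4 (0.44 log units; beyond the scatter) can be tied to that stereocentre alone because of one thing: the fact that compounds 2 and 4 differ only in the configuration as drawn

From the compounds shown here alone, whether the low numbers are particular to chloro, or would also appear with fluoro, bromo, hydroxyl or methyl on this carbon, stays open. Going by these compounds, it is also open whether configuration would count in the same way with an amine at this position.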